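The compounds below may be only part of what the source reports. "The series", "measured", "known", "first", "only" and "open" are said of these compounds alone.

In a functional assay on QGY-7703 cells (Homo sapiens) for cytotoxicity, read by MTT assay, with a stated time of 24 h (on this read-out higher numbers stand for weaker inhibition and lower numbers for stronger inhibition), compound 1 `O=C1/C(=C/c2ccncc2)CNC/C1=C\c1ccccc1F` gives 14200 nM. Compound 2 `Cc1ccc(S(=O)(=O)N2C/C(=C\c3ccncc3)C(=O)/C(=C/c3ccccc3F)C2)cc1` reaches only a limit of the assay, > 20000 nM. Compound 3 `O=C1/C(=C/c2ccncc2)CN(S(=O)(=O)c2ccc([N+](=O)[O-])cc2)C/C1=C\c1ccccc1F` gives 8800 nM, within the scatter of compound 1, with an at least 2.2-fold lower number from compound 2 to compound 3 (0.35 log units; beyond the scatter) beyond the scatter. Compound 4 `O=C1/C(=C/c2ccncc2)CN(S(=O)(=O)c2ccc(Cl)cc2)C/C1=C\c1ccccc1F` differs from compound 3 by chloro in place of nitro on an aromatic carbon, with chloro in place of nitro on an aromatic carbon. The step at this same place is an at least 2.2-fold lower number from compound 2 to compound 3 (0.35 log units; beyond the scatter), where nitro replaced methyl. The sulfonyl step, an at least 1.4-fold higher number from compound 1 to compound 2 (0.14 log units; that floor lies within the scatter), bears only indirectly, and its floor lies within the scatter. Only a small rise in this assay is therefore expected, not clearly beyond the scatter. The expected step is a 1.4-fold higher number from compound 3 to compound 4 (0.13 log units; within the scatter). Compound 4 is estimated at 12000 nM, with an expected range of 5500 nM to 26000 nM.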

Compound 4, half-maximal inhibitory concentration: 12500 nM
Compound 4: the middle estimate sits 1.0-fold (0.02 log units) below what was measured; measured number inside the range.
By their numbers in this assay, from the lowest: compounds 3, 4 and 1 (each within the scatter of the next). At a limit, above all of these: compound 2.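

In this assay, chloro in place of nitro at this place on the aromatic ring leaves the reading within the scatter (a 1.4-fold higher number from compound 3 to compound 4 (0.15 log units; within the scatter)). Replacing hydrogen on the ring amine nitrogen with (4-chlorophenyl)sulfonyl likewise gives no readable change (a 1.1-fold lower number from compound 1 to compound 4 (0.06 log units; within the scatter)). Chloro in place of methyl can be read only as a floor that lies within the scatter (an at least 1.6-fold lower number from compound 2 to compound 4 (0.20 log units; that floor lies within the scatter)), since compound 2 rests on a limit: (the limit of > 20000 nM in this assay, at which 1 of the 4 values shown sits).

From the compounds shown here alone, whether an amine or a carboxylic acid at this place would separate from chloro and nitro stays open. So does the true reading of compound 2.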